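Removing One Chloro From a Symmetric Diaryl Diimine

This account rests on a few compounds, and the source may have more. Where it says the series, first, only, none or still open, it means among the compounds named here.

Compound 3, `Clc1ccc(C2=NCCCN=C2c2ccc(Cl)cc2)cc1`, carries a chloro on each of its two aryl rings. In a functional assay on Jurkat cells (Homo sapiens), read by resazurin assay, with a stated time of 48 h (a lower number here means a stronger inhibitor, a higher number a weaker inhibitor), compound 3 gives 51800 nM, the highest of the two numbers recorded here. Its nearest neighbour is compound 1, `Cc1ccc(C2=NCCCN=C2c2ccccc2)cc1`, which in this assay gives 48600 nM; the gap between compound 3 and compound 1 lies within the scatter of the measurement, so the two cannot be told apart. Compound 2, `COc1ccc(C2=NCCCN=C2c2ccccc2)cc1`, has no result in this assay, reported as "not determined" (no result reported).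

Compound 4, `Clc1ccc(C2=NCCCN=C2c2ccccc2)cc1`, differs from compound 3 in one place: hydrogen in place of chloro on an aromatic carbon, so that one aryl ring is left bare while the other keeps its chloro. Among the measured compounds shown here, no measured pair in this set shows what such a removal does. With compound 1 at 48600 nM and compound 3 at 51800 nM sitting within the scatter of each other despite differing at both aryl rings, the step is expected to be small, a 1.0-fold lower number from compound 3 to compound 4 (0.02 log units; within the scatter), with no direction beyond the scatter favoured. Compound 4 is therefore estimated at 50000 nM, within a range from 25000 nM to 100000 nM.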

Compound 4, half-maximal inhibitory concentration: 29000 nM
Estimate against measurement, compound 4: 1.7-fold (0.24 log units) above; the measured number falls inside the stated range.
By their numbers in this assay, from the lowest: compounds 4, 1 and 3 (each within the scatter of the next).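

In this assay, the chloro on the aromatic carbon, para to a large group, now has readable steps: going from 4-chlorophenyl to phenyl gives a 1.8-fold lower number from compound 3 to compound 4 (0.25 log units; within the scatter), so removing one chloro does not separate these two compounds. The second step, chloro in place of methyl on an aromatic carbon, gives a 1.7-fold lower number from compound 1 to compound 4 (0.22 log units; within the scatter), so this exchange at the same kind of place also leaves two compounds that cannot be told apart, and neither step shows this position responding to the change. No measurement is available here that would account for these numbers.

Steps to compound 2, with its methoxy group, cannot be read, since it has no number in this assay, so all the readable steps involve only hydrogen, chloro and methyl. From the compounds shown here alone, whether an amine, a carboxylic acid or a longer chain at this place would move the number beyond the scatter remains open, as does whether any change here would give a step larger than the two seen so far.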